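Benzyl-substituted fused cores: amino for chloro, second pair

The compounds below may be only part of what the source reports. "The series", "measured", "known", "first", "only" and "open" are said of these compounds alone.

Measured compounds:
compound 1 `Nc1nc(Cl)c2ncn(Cc3ccc(CCl)cc3)c2n1`: 57500 nM
compound 2 `ClCc1cccc(Cn2cnc3c(Cl)nc(Cl)nc32)c1`: 61700 nM
compound 3 `ClCc1ccc(Cn2cnc3c(Cl)nc(Cl)nc32)cc1`: 61700 nM

In a functional assay on OVCAR-4 cells (Homo sapiens) for cytotoxicity, read by sulforhodamine B assay, with a stated time of 48 h (a higher number here means that more compound is tolerated, a lower number that less compound is tolerated), compound 3 gives 61700 nM, while compound 1 gives 57500 nM. The change between them is amino in place of chloro on an aromatic carbon, and the measured step is a 1.1-fold lower number from compound 3 to compound 1 (0.03 log units; within the scatter). Compound 2 gives 61700 nM in this assay; compound 2 and compound 3 have the same atoms joined differently, and the difference between the two cores is not broken down here.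

Compound 4 `Nc1nc(Cl)c2ncn(Cc3cccc(CCl)c3)c2n1` is not yet measured. It differs from compound 2 by amino in place of chloro on an aromatic carbon, the same change as made from compound 3 to compound 1, at a place described in identical words. In this assay the step for compound 4 is expected to be a 1.1-fold lower number from compound 2 to compound 4 (0.03 log units; within the scatter), resting on the measured step of a 1.1-fold lower number from compound 3 to compound 1 (0.03 log units; within the scatter). The expected value for compound 4 is 58000 nM, with a likely range from 35000 nM to 95000 nM.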

Compound 4, concentration lethal to 50% of the cells: 9540 nM
Compound 4: the middle estimate sits 6.1-fold (0.78 log units) above what was measured, outside the stated range (below it).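

In this assay, amino in place of chloro on an aromatic carbon gives a 6.5-fold lower number from compound 2 to compound 4 (0.81 log units; beyond the scatter), and this step does not match the one on the other core: the same change on two cores in this assay, a 1.1-fold lower number (0.03 log units; within the scatter) from compound 3 to compound 1 and a 6.5-fold lower number (0.81 log units; beyond the scatter) from compound 2 to compound 4, 6.0-fold (0.78 log units) apart, beyond the scatter of two such steps. In this series, the size of the step on one core is therefore not a safe guide to its size on the other. The two pairs show that the outcome of this change depends on the core it is made on, but not why, and they give no rule for any further core.

The compounds shown leave open whether the lower number of compound 4 is specific to amino. Also open, on these data alone, is how a methylamino or a hydroxyl group in place of that chloro would behave on each core.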